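A few compounds are considered here, and "the series" means these few. Any claim that something is new, unique, unknown or untested is made for them only; others in the source may bear on it.

Compound 1 `CN1C[C@@H](c2ccccc2)[C@@]2(Cc3ccccc3C2=O)[C@@]12C(=O)Nc1ccccc12` gives 42.5% in a functional assay on the whole organism (strain Wister albino) for inhibition, with Rattus norvegicus as the target, read by paw edema, with stated times of 1 h and 3 h, at a dose of 50 mg/kg by the intraperitoneal route; a higher number here means more inhibition at the dose given (going by the name of the read-out), a lower number less inhibition.
Compound 2 `CN1C[C@@H](c2ccc(F)cc2)[C@@]2(Cc3ccccc3C2=O)[C@@]12C(=O)Nc1ccccc12` gives 21.1% in this assay.
Compound 3 `CN1C[C@@H](c2cccs2)[C@@]2(Cc3ccccc3C2=O)[C@@]12C(=O)Nc1ccccc12` gives 32.6% in this assay.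

In this assay compound 3 stands second highest of the three numbers. Its nearest is compound 1, with a number 9.9 percentage points lower from compound 1 to compound 3 (within the scatter), a step within the scatter; its furthest is compound 2, with a number 11.5 percentage points higher from compound 2 to compound 3 (beyond the scatter), a step beyond the scatter. Compound 4 `CN1C[C@@H](c2ccco2)[C@@]2(Cc3ccccc3C2=O)[C@@]12C(=O)Nc1ccccc12` has not yet been measured. It differs from compound 3 in one place: furan-2-yl in place of thiophen-2-yl on a saturated ring carbon. Among the compounds with values here, two measured steps bear on this change, since both alter the group on the same saturated ring carbon: a number 9.9 percentage points lower from compound 1 to compound 3 (within the scatter), which puts thiophen-2-yl in place of phenyl and stays within the scatter, and a number 11.5 percentage points higher from compound 2 to compound 3 (beyond the scatter), which is beyond the scatter but modest. Neither step exchanges one five-membered aromatic group for another, so they only show that changes at this carbon have so far been small. The step expected here is therefore none beyond the scatter, a number 2.6 percentage points lower from compound 3 to compound 4 (within the scatter). Compound 4 is estimated at 30% in this assay, with an expected range from 17% to 43%.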

Compound 4, a percentage reported as inhibition, in the whole organism at one dose (the size of the read-out at that dose, not a potency): 38.8%
Compound 4: the middle estimate sits 8.8 percentage points below what was measured; the measured number falls inside the stated range.
By their numbers in this assay, from the lowest: compound 2; then compounds 3, 4 and 1 (each within the scatter of the next).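

In this assay, furan-2-yl in place of thiophen-2-yl gives a number 6.2 percentage points higher from compound 3 to compound 4 (within the scatter), so at this saturated ring carbon the two five-membered aromatic rings cannot be told apart. Furan-2-yl also cannot be told apart from phenyl, with a number 3.7 percentage points lower from compound 1 to compound 4 (within the scatter), whereas the gap to 4-fluorophenyl is larger, with a number 17.7 percentage points higher from compound 2 to compound 4 (beyond the scatter), which leaves compound 2 as the only one of the four that stands clearly lower. Nothing measured here offers a reason for these numbers.

Still open, going by these compounds, is whether a ring carbon can carry a non-aromatic group such as cyclohexyl or a longer chain such as n-butyl and keep this level of inhibition. It is also unknown whether the lower number of compound 2 is particular to fluoro, or whether chloro or methoxy on the same phenyl ring would behave alike.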